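Benzoyl for chloro on the anilide of compound 3

This account rests on a few compounds, and the source may have more. Where it says the series, first, only, none or still open, it means among the compounds named here.

Compound 3, with the structure `O=C(CCCCCCNC(=O)C(O)(O)C(F)(F)F)Nc1ccc(Cl)cc1`, gives 4230 nM in a functional assay on HCT-116 cells (Homo sapiens) for inhibition, read by colorimetric assay, with a stated time of 3 days (on this read-out higher numbers stand for weaker inhibition and lower numbers for stronger inhibition), which places it second highest of the three numbers at hand: compound 2, `O=C(CCCCCCNC(=O)C(O)(O)C(F)(F)F)Nc1cccc(Br)c1`, gives 3060 nM, a difference that lies within the scatter, while compound 1, `O=C(CCCCCCNC(=O)C(O)(O)C(F)(F)F)Nc1nccs1`, gives 10800 nM. The measured steps are a 3.5-fold lower number from compound 1 to compound 2 (0.55 log units; beyond the scatter) and a 2.6-fold lower number from compound 1 to compound 3 (0.41 log units; beyond the scatter), both modest, and a 1.4-fold higher number from compound 2 to compound 3 (0.14 log units; within the scatter), which is within the scatter. Compound 4, `O=C(CCCCCCNC(=O)C(O)(O)C(F)(F)F)Nc1ccc(C(=O)c2ccccc2)cc1`, differs from compound 3 in one place: benzoyl in place of chloro on an aromatic carbon. Among the measured compounds shown here, none of the measured steps exchanges a halogen for a benzoyl group, so no step bears on this change directly; what the steps do show is that changes to the aryl group on the amide-type nitrogen have moved this assay by modest amounts at most. He therefore expects a step from compound 3 to compound 4 of a 1.3-fold lower number from compound 3 to compound 4 (0.12 log units; within the scatter) in this assay, small and uncertain in direction. His estimate for compound 4 in this assay is 3200 nM, with a range from 1000 nM to 10000 nM.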

Compound 4, half-maximal inhibitory concentration: > 40000 nM
Compound 4 ended at the assay's limit; the forecaster's own chance of this, stated with the estimate: 5%; middle value at least 12-fold (1.09 log units) from the limit.
By their numbers in this assay, from the lowest: compounds 2 and 3 (each within the scatter of the next); then compound 1. At a limit, above all of these: compound 4.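

Among compounds 1, 2 and 3, changing the aryl group on the amide-type nitrogen had moved this assay only modestly. Benzoyl in place of chloro, on the same aromatic carbon and para to a large group, now gives an at least 9.4-fold higher number from compound 3 to compound 4 (0.97 log units; beyond the scatter), which shows that this position is not indifferent to what it carries and that a single exchange there can take the compound out of the measurable range. Compound 4 stands at a limit of the assay and not at a number: the limit of > 40000 nM in this assay, at which 1 of the 4 values shown sits.

The compounds shown do not separate the carbonyl of the benzoyl group from its aromatic ring. From the compounds shown here alone, whether an acetyl group or a phenyl group on that carbon would behave like chloro or like benzoyl remains open, as does how far compound 4 lies beyond the limit.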